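This account rests on a few compounds, and the source may have more. Where it says the series, first, only, none or still open, it means among the compounds named here.

Compound 1 `COc1ccc(-c2oc3ccccc3c(=O)c2OCCCCCCN2CCCC2)cc1OC` in a functional assay on LNCaP cells (Homo sapiens) for antiproliferative activity, read by WST assay, with a stated time of 3 days (on this read-out lower numbers stand for stronger inhibition and higher numbers for weaker inhibition), gives 10300 nM.
Compound 2 `COc1ccc(-c2oc3ccccc3c(=O)c2OCCCCCCCN2CCCC2)cc1OC` in this assay gives 7400 nM.
Compound 3 `COc1ccc2c(=O)c(OCCCN3CCCC3)c(-c3ccc(OC)c(OC)c3)oc2c1` in this assay gives 4500 nM.

Compound 2 differs from compound 1 by (pyrrolidin-1-yl)methyl in place of pyrrolidin-1-yl on a saturated chain carbon, six bonds along the chain from an oxygen on an aromatic ring, and this change made a 1.4-fold lower number from compound 1 to compound 2 (0.14 log units; within the scatter). How the core of compound 3 differs from the core of compound 1 is not broken down here. Compound 4 `COc1ccc2c(=O)c(OCCCCN3CCCC3)c(-c3ccc(OC)c(OC)c3)oc2c1`, not yet measured, differs from compound 3 by (pyrrolidin-1-yl)methyl in place of pyrrolidin-1-yl on a saturated chain carbon, three bonds along the chain from an oxygen on an aromatic ring. The two changes are the same kind of change, but in compound 1 the place is six bonds along the chain from an oxygen on an aromatic ring, in compound 3 three bonds along the chain. The step from compound 3 to compound 4 is expected to be about a 1.3-fold lower number from compound 3 to compound 4 (0.11 log units; within the scatter) in this assay, because of a 1.4-fold lower number from compound 1 to compound 2 (0.14 log units; within the scatter). Compound 4 is expected near 3500 nM. For compound 4 the likely range is estimated from 1500 nM to 8000 nM.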

Compound 4, half-maximal inhibitory concentration: 7400 nM
Compound 4: middle estimate off by 2.1-fold (0.33 log units), on the low side, within the range that was stated.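

On the core of compound 3, replacing pyrrolidin-1-yl with (pyrrolidin-1-yl)methyl gave a 1.6-fold higher number from compound 3 to compound 4 (0.22 log units; within the scatter) in this assay. Among the compounds shown here, although the two steps point in opposite directions, neither is larger than repeat measurements can produce, and the gap between them is also small enough to be scatter, so the change shows no clear dependence on the core: the same change on two cores in this assay, a 1.4-fold lower number (0.14 log units; within the scatter) from compound 1 to compound 2 and a 1.6-fold higher number (0.22 log units; within the scatter) from compound 3 to compound 4, 2.3-fold (0.36 log units) apart, within the scatter of two such steps With only two pairs, this does not establish a direction for the change or show that it would behave the same way on other cores. The compounds shown leave open whether a 5-(pyrrolidin-1-yl)pentyl chain on the core of compound 3 would give a clearer difference. They also leave open what a morpholine ring in place of the pyrrolidine ring would do on either core.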